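From 1-hydroxyethyl to cyano in a microsomal stability test

The compounds below may be only part of what the source reports. "The series", "measured", "known", "first", "only" and "open" are said of these compounds alone.

Compound 1 `COc1ccc(-c2cc(Cl)c3c(N)ncnn23)cc1N1CCN(C(C)=O)C(C)(C)C1=O`: 91%
Compound 2 `CC(=O)N1CCN(c2cc(-c3cc(Cl)c4c(N)ncnn34)ccc2C(C)O)C(=O)C1(C)C`: 100%

Both compounds were tested in an ADME assay on microsomes from liver (Rattus norvegicus) for metabolic stability, read by LC-MS, using NADPH, with stated times of 6 min and 10 min, tested at 0.5 uM; on this read-out lower numbers stand for a less stable compound and higher numbers for a more stable compound. Compound 2 gives 100% and compound 1 gives 91%, so the two values lie within the scatter of each other.

Compound 3 `CC(=O)N1CCN(c2cc(-c3cc(Cl)c4c(N)ncnn34)ccc2C#N)C(=O)C1(C)C` differs from compound 2 in one group: cyano in place of 1-hydroxyethyl on an aromatic carbon. In words, this is cyano in place of 1-hydroxyethyl on an aromatic carbon.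

Within the data shown here, only one measured step bears on this change: a number 9 percentage points higher from compound 1 to compound 2 (within the scatter), which exchanged methoxy for 1-hydroxyethyl. Among the measured compounds shown here, no measured compound carries cyano, so this evidence is thin. With that single step as the guide, no change beyond the scatter is expected in this assay. The expected step is a number 8 percentage points lower from compound 2 to compound 3 (within the scatter). For compound 3 the estimate is 92%, with an expected range from 78% to 100%.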

Compound 3, percent of the compound remaining: 89%
For compound 3 the middle estimate is 3 percentage points above the measured one, and the stated range covers the measured number.
By their numbers in this assay, from the lowest: compounds 3, 1 and 2 (each within the scatter of the next, the first and the last beyond it).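

In this assay, among these compounds, cyano in place of 1-hydroxyethyl on this aromatic carbon gives a number 11 percentage points lower from compound 2 to compound 3 (beyond the scatter) and is the first step at this position to pass beyond the usual scatter. Cyano in place of methoxy gives a number 2 percentage points lower from compound 1 to compound 3 (within the scatter) and so does not separate these two groups, which leaves methoxy within the scatter of both cyano and 1-hydroxyethyl. Nothing measured here gives a reason for the gap between cyano and 1-hydroxyethyl.

As far as these compounds go, it remains open whether an amine, a carboxylic acid or a longer chain ending in a hydroxyl group on this carbon would read closer to 1-hydroxyethyl or to cyano in this assay. From the compounds shown here alone, all three compounds also share one core, so it is equally open whether the same step would appear on a different core.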